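This account rests on a few compounds, and the source may have more. Where it says the series, first, only, none or still open, it means among the compounds named here.

Measured so far:
- compound 1 `Cc1ccccc1/C(CCN1CCN(c2ccccn2)CC1)=N\O`: 72%
- compound 2 `CO/N=C(/CCN1CCN(c2ccccn2)CC1)c1ccccc1Cl`: 73%
- compound 3 `CO/N=C(\CCN1CCN(c2ccccn2)CC1)c1ccccc1C`: 80%

In a functional assay on HEK293 cells with D(4) dopamine receptor (Homo sapiens) as the target, read by FLIPR (on this read-out higher numbers stand for larger maximal responses and lower numbers for smaller maximal responses), compound 3 gives 80%, the highest of the three numbers to hand. The nearest is compound 2 with 73%, a number that lies lower but within the scatter; the furthest is compound 1 with 72%, also lower and also within the scatter. The three compounds thus sit in one band on this read-out, and no ordering among them can be read from these numbers.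

Going by the values given here, compound 4 `CO/N=C(/CCN1CCN(c2ccccn2)CC1)c1ccccc1C` is the pair to compound 3. the two compounds have the same atoms and bonds and differ only in configuration as drawn: 1 of 1 stereo elements differ; a double bond is drawn E in compound 3 and Z in compound 4 No step between two measured compounds of this kind is available, so there is nothing to calibrate the size of such a change against. As the three measured compounds, which differ more widely from one another than compound 3 does from compound 4, all fall within the scatter of each other, no movement beyond the scatter is expected from the change in configuration as drawn in this assay.

Compound 4 is therefore expected to give about 75% in this assay, with a range from 60% to 88%. The estimated step of a number 5 percentage points lower from compound 3 to compound 4 (within the scatter) is small and within the scatter.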

Compound 4, largest response reached (reported as efficacy), in percent of the reference or control that the assay uses: 72%
Compound 4: middle estimate off by 3 percentage points, on the high side; measured number inside the range.
By their numbers in this assay, from the lowest: compounds 1, 4, 2 and 3 (each within the scatter of the next).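

Working notes on the series: in this assay the first step that isolates the double-bond configuration is a number 8 percentage points lower from compound 3 to compound 4 (within the scatter) and, as printed, it gives no separation of this pair. The two other single-place comparisons behave alike: methyl in place of chloro on an aromatic carbon gives a number 1 percentage points lower from compound 2 to compound 4 (within the scatter) and methyl in place of hydrogen on an oxygen gives no change at the digits printed from compound 1 to compound 4 (within the scatter) so that in this assay none of the three changes moves the maximal response beyond the scatter. The pair of compound 3 and compound 4 is the tightest comparison in the set, and its reading needs no allowance for any other structural change: the fact that compounds 3 and 4 differ only in the configuration as drawn.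

Still open, from the compounds shown here alone, is whether any change on this scaffold separates from the band at all, for example an ethyl or a longer chain on the oxygen, or trifluoromethyl or methoxy on the aromatic carbon in place of methyl. Also open, going by these compounds, is whether the same E and Z pairing gives the same reading with chloro on the aromatic carbon, or with hydrogen on the oxygen.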